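The source may hold more compounds than are shown below. What is called first, only, known or untested is meant among the compounds shown, and "the series" means these compounds.

- compound 1 `Cc1ccc(/C=C/C(=O)Nc2nnc(-c3ccc(Cl)cc3)s2)cc1` gives 1.25 ug/mL
- compound 2 `Cc1ccc(/C=C/C(=O)Nc2nnc(-c3ccc(C)cc3)s2)cc1` gives 1.08 ug/mL

For the measured compounds named here, in a functional assay on A549 cells (Homo sapiens) for antiproliferative activity, read by MTT assay, with a stated time of 48 h (a higher number here means a weaker inhibitor, a lower number a stronger inhibitor), compound 1 gives 1.25 ug/mL, which lies within the scatter of the only other measured compound, compound 2. Compound 3 `O=C(/C=C/c1ccc(C(F)(F)F)cc1)Nc1nnc(-c2ccc(Cl)cc2)s1` has not been measured. It differs from compound 1 as follows: trifluoromethyl in place of methyl on an aromatic carbon. This puts trifluoromethyl in place of methyl on an aromatic carbon, para to a large group. Going by the values given here, the only measured step, a 1.2-fold lower number from compound 1 to compound 2 (0.06 log units; within the scatter), swaps a different pair of groups, so it bears only indirectly, and it stayed small. No change beyond the scatter is therefore expected, and the expected step is a 1.0-fold lower number from compound 1 to compound 3 (0.02 log units; within the scatter). The estimate for compound 3 is 1.2 ug/mL, with an expected range of 0.4 ug/mL to 3.5 ug/mL.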

Compound 3, half-maximal inhibitory concentration: 3.09 ug/mL
The estimate for compound 3 lay 2.6-fold (0.41 log units) below the measured number, and the stated range covers the measured number.
By their numbers in this assay, from the lowest: compounds 2 and 1 (each within the scatter of the next); then compound 3.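

In this assay, this position, para to a large group, proves sensitive to what sits on it: trifluoromethyl in place of methyl gives a 2.5-fold higher number from compound 1 to compound 3 (0.39 log units; beyond the scatter). For the compounds shown here, the earlier step, methyl in place of chloro at a different place, stayed within the scatter, so this is the first change here that clearly moves the number. Nothing available explains the shift. Open, on these data alone, is whether a methoxy group or an amine at this position would keep the number close to that of compound 1 or move it further.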